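A few compounds are considered here, and "the series" means these few. Any claim that something is new, unique, unknown or untested is made for them only; others in the source may bear on it.

Going by the values given here, compound 1 `NC(=O)c1cnc2c(c1Cl)CCN2` is the one compound in this set with a defined figure. Among the compounds with values here, in an assay on isolated protein for inhibition of Nicotinamide N-methyltransferase (Homo sapiens), read by luminescence, with a stated time of 20 min (on this read-out higher numbers stand for weaker inhibition and lower numbers for stronger inhibition), compound 1 gives 92 nM, the only actual number recorded. Within the data shown here, compound 2 `CNc1ncc(C(N)=O)c(C)c1C` yields in this assay only a limit, > 10000 nM. the limit of > 10000 nM in this assay, at which 1 of the 2 values shown sits, is where that second value sits, so compound 1 stands alone as the single measured number, with nothing alongside it that would place it higher or lower. The step to compound 3 `NC(=O)c1cnc2c(c1)CCN2` is hydrogen in place of chloro on an aromatic carbon. Among the measured compounds shown here, no step between two measured compounds exists here to guide the size of this change. Compound 3 is expected to come out weaker in this assay, with an estimated step of a 4.3-fold higher number from compound 1 to compound 3 (0.64 log units; beyond the scatter) that goes beyond the usual scatter. On that basis compound 3 is estimated at 400 nM, within a range from 120 nM to 1500 nM.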

Compound 3, half-maximal inhibitory concentration: 175 nM
Compound 3: the middle estimate sits 2.3-fold (0.36 log units) above what was measured; low and high end bracket the measured number.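

Going by these compounds alone, the step of a 1.9-fold higher number from compound 1 to compound 3 (0.28 log units; within the scatter) is the first reading of this position, on the aromatic carbon ortho to a carbamoyl group and opposite the ring nitrogen, in this assay. With the step within the scatter, chloro and hydrogen at this place cannot be told apart here, so chloro is not required for a measured value on the shared core. Nothing measured here bears on why the two compounds read alike.

The compounds shown leave open how a methoxy group, a bromine atom or a nitrile would read on this same aromatic carbon, where only a pair of small substituents on the shared core can be compared. They also leave open what a carboxylic acid in place of the carbamoyl group would give.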